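Chlorobenzylsulfanyl dihydropyrimidine amides: chlorine position swap

This account rests on a few compounds, and the source may have more. Where it says the series, first, only, none or still open, it means among the compounds named here.

Four compounds built on two related cores. Compound 1 `CC1=C(C(=O)Nc2ccc(F)cc2)C(c2ccc([N+](=O)[O-])cc2)N=C(SCc2ccccc2Cl)N1` and compound 2 `CC1=C(C(=O)Nc2ccc(F)cc2)C(c2ccc([N+](=O)[O-])cc2)N=C(SCc2cccc(Cl)c2)N1` share one core, compound 3 `CC1=C(C(=O)Nc2ccc([N+](=O)[O-])cc2)C(c2cccc([N+](=O)[O-])c2)N=C(SCc2ccccc2Cl)N1` and compound 4 `CC1=C(C(=O)Nc2ccc([N+](=O)[O-])cc2)C(c2cccc([N+](=O)[O-])c2)N=C(SCc2cccc(Cl)c2)N1` share another; the difference between the two cores is not broken down here.

In a functional assay on the whole organism (artery, strain albino) with Rattus norvegicus as the target, with a stated time of 60 min, at a dose of 10 mg/kg by the oral route (a higher number here means more inhibition at the dose given (going by the name of the read-out), a lower number less inhibition), compound 1 gives 6.2%. In this assay compound 2 gives 7.2%. The change from compound 1 to compound 2 is 3-chlorophenyl in place of 2-chlorophenyl on a saturated chain carbon bound to a sulfur, and the step it made is a number 1 percentage points higher from compound 1 to compound 2 (within the scatter). In this assay compound 3 gives 6.7%. The three measured values all lie within the scatter of one another, so no order among compound 1, compound 2 and compound 3 can be read from them.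

Compound 4 carries the same change on the core of compound 3: 3-chlorophenyl in place of 2-chlorophenyl on a saturated chain carbon bound to a sulfur. The place of the change reads the same in both pairs, so it is the same change applied to a different core. It occurs twice among the compounds shown, once measured and once not.

The expected step is a number 0.8 percentage points higher from compound 3 to compound 4 (within the scatter), because a number 1 percentage points higher from compound 1 to compound 2 (within the scatter) stayed within the scatter. Within the data shown here, no other pair bearing this change is available, so the expectation rests on that single measured pair and on the three values sitting close together. In this assay compound 4 is expected to give about 7.5%, with a likely range from 0% to 17%.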

Compound 4, a percentage reported as inhibition, in the whole organism at one dose (the size of the read-out at that dose, not a potency): 8.2%
Compound 4: the middle estimate sits 0.7 percentage points below what was measured, within the range that was stated.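

On the second core, 3-chlorophenyl in place of 2-chlorophenyl on a saturated chain carbon bound to a sulfur gives a number 1.5 percentage points higher from compound 3 to compound 4 (within the scatter) in this assay, so this step, like the earlier one, cannot be told from the usual spread of repeat measurements. The two steps also do not differ from each other, so on the two cores shown the change behaves alike, with no sign that the core alters its outcome: the same change on two cores in this assay, a number 1 percentage points higher (within the scatter) from compound 1 to compound 2 and a number 1.5 percentage points higher (within the scatter) from compound 3 to compound 4, 0.5 percentage points apart, within the scatter of two such steps

This does not show that 3-chlorophenyl gives more inhibition than 2-chlorophenyl on either core, and two pairs read at one dose and one time cannot establish how the change behaves on other cores or whether a real effect too small to resolve lies beneath the scatter.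

On these data alone, it remains open whether any other group at this place would move the read-out beyond the scatter, for example an unsubstituted benzyl, a longer alkyl chain, or a benzyl bearing an amine or a carboxylic acid in place of the chlorine. Among these compounds, the effect of the core itself also stays open, as compound 1 and compound 3 differ in more than one place and no single-change step links the two cores.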